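Compound 4: hexyl addition to the limit-bound compound 1

A few compounds are considered here, and "the series" means these few. Any claim that something is new, unique, unknown or untested is made for them only; others in the source may bear on it.

In a functional assay on A549 cells (Homo sapiens) for antiproliferative activity, read by MTT assay, with a stated time of 72 h (a lower number here means a stronger inhibitor, a higher number a weaker inhibitor), compound 1 (`CCCCCCCCNC[C@@H]1OC[C@H](N)[C@@H]1O`) gives only a limit, > 128000 nM, not a number. Compound 4 (`CCCCCCCCCCCCCCNC[C@@H]1OC[C@H](N)[C@@H]1O`) keeps the core and configuration of compound 1 and differs by hexyl in place of hydrogen on a saturated chain carbon, eight bonds along the chain from an amine nitrogen.

Among the measured compounds shown here, two measured steps bear on this change. The configuration step, an at least 1.7-fold lower number from compound 1 to compound 3 (0.25 log units; that floor lies within the scatter), ends at compound 3 (`CCCCCCCCNC[C@@H]1OC[C@H](N)[C@H]1O`), which gives 71800 nM. For the measured compounds named here, the only measured chain step is butyl in place of hydrogen at the same place, and compound 2 (`CCCCCCCCCCCCNC[C@@H]1OC[C@H](N)[C@H]1O`) gives 41100 nM. Going by the values given here, that step, a 1.7-fold higher number from compound 2 to compound 3 (0.24 log units; within the scatter), belongs to the configuration of compound 3, and no chain step has been measured in the configuration of compound 1. Hexyl is also a larger addition than butyl.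

A modest move towards a lower number is therefore expected, though the evidence for it is weak and another limit remains possible. The expected change is an at least 2.8-fold lower number from compound 1 to compound 4 (0.45 log units; beyond the scatter). For compound 4 the estimated value is 45000 nM, with an expected range of 15000 nM to 120000 nM.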

Compound 4, half-maximal inhibitory concentration: 2850 nM
Compound 4: the middle estimate sits 16-fold (1.20 log units) above what was measured, outside the stated range (below it).
By their numbers in this assay, from the lowest: compound 4; then compounds 2 and 3 (each within the scatter of the next). At a limit, above all of these: compound 1.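

In this assay, among the compounds shown here, hexyl on a saturated chain carbon, eight bonds along the chain from an amine nitrogen, gives an at least 44-fold lower number from compound 1 to compound 4 (1.65 log units; beyond the scatter), the only chain step measured in the configuration of compound 1. For the compounds shown here, the only other chain step, a 1.7-fold higher number from compound 2 to compound 3 (0.24 log units; within the scatter), is butyl in the configuration of compound 3, so a large change at this place appears here only with hexyl in the configuration of compound 1. Compound 1 gives only a limit, so the size of this step is a floor and not a number: the limit of > 128000 nM in this assay, at which 1 of the 4 values shown sits.

On these data alone, whether hexyl at this place gives a step of similar size in the configuration of compound 3 remains open, so chain length and configuration cannot yet be separated. Also open, as far as these compounds go, is how a longer chain, or an amine or a carboxylic acid at the same place, would read.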